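This account rests on a few compounds, and the source may have more. Where it says the series, first, only, none or still open, it means among the compounds named here.

Measured so far in a functional assay on U-251 cells (Homo sapiens) for antiproliferative activity, read by sulforhodamine B assay, with a stated time of 48 h, tested at 50 uM; a lower number here means less inhibition, a higher number more inhibition at the concentration tested (going by the name of the read-out): compound 1 `CC1=CC[C@H](C(C)C)c2cc(C)c(OC(=O)c3ccccc3)cc21` gives 25.8%; compound 2 `CC1=CC[C@H](C(C)C)c2cc(C)c(OC(=O)c3ccc(Cl)cc3)cc21` gives 25.6%.

For the measured compounds named here, compound 2 holds the lowest of the two numbers in this assay, its only neighbour being compound 1, and the step of a number 0.2 percentage points lower from compound 1 to compound 2 (within the scatter) leaves the two indistinguishable. Compound 3 `COc1ccc(C(=O)Oc2cc3c(cc2C)[C@@H](C(C)C)CC=C3C)cc1` differs from compound 2 in one place: methoxy in place of chloro on an aromatic carbon. Going by the values given here, the single measured step, a number 0.2 percentage points lower from compound 1 to compound 2 (within the scatter), is the only one that bears on this exchange at the same place, and it was small. For compound 3 a step of a number 0.1 percentage points lower from compound 2 to compound 3 (within the scatter) is therefore expected, nothing beyond the scatter. Compound 3 is estimated at 25.5%, ranging from 13% to 38%.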

Compound 3, a percentage reported as inhibition, at one concentration (the size of the read-out at that concentration, not a potency): 37%
Beside the measured number, compound 3's estimate is 11.5 percentage points below it, within the range that was stated.
By their numbers in this assay, from the lowest: compounds 2 and 1 (each within the scatter of the next); then compound 3.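

In this assay the place para to a large group does respond to its substituent: methoxy gives a number 11.4 percentage points higher from compound 2 to compound 3 (beyond the scatter) against chloro, and a number 11.2 percentage points higher from compound 1 to compound 3 (beyond the scatter) against hydrogen. Chloro and hydrogen stood within the scatter of each other, so the exchange of the earlier pair gave no sign of this sensitivity, and methoxy is the first group here to separate from the others. Nothing measured on these compounds explains the rise. Open, on these data alone, is whether the rise stays with methoxy alone or also appears with ethoxy, a longer chain, or an amine at the same place.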